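Ring nitrogen substituent: from compound 2 to compound 4

The compounds below may be only part of what the source reports. "The series", "measured", "known", "first", "only" and "open" are said of these compounds alone.

Three compounds share the bis(4-fluorophenyl)methyl thioether or sulfoxide unit and differ mainly at the amine nitrogen in the ring. In an assay on membranes from striatum (strain Sprague-Dawley) for displacement of a labelled ligand from sodium-dependent dopamine transporter (Rattus norvegicus), read by scintillation counting, with a stated time of 120 min (a lower number here means a stronger inhibitor, a higher number a weaker inhibitor), compound 1 `Fc1ccc(C(SCCNC2CCN(Cc3ccc(Cl)cc3)CC2)c2ccc(F)cc2)cc1` gives 39.6 nM, compound 3 `O=C(c1cc2ccccc2[nH]1)N1CCC(NCCSC(c2ccc(F)cc2)c2ccc(F)cc2)CC1` gives 177 nM, and compound 2 `[O-][S+](CCNC1CCN(CC(O)Cc2ccccc2)CC1)C(c1ccc(F)cc1)c1ccc(F)cc1` gives 91.8 nM. Compound 2 stands second highest of the three numbers; its value and that of compound 3 lie within the scatter of each other, while compound 1 sits clearly lower.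

Compound 4 `O=C(c1ccc(F)cc1)N1CCC(NCC[S+]([O-])C(c2ccc(F)cc2)c2ccc(F)cc2)CC1` is compound 2 with (4-fluorophenyl)carbonyl in place of 2-hydroxy-3-phenylpropyl on an amine nitrogen in a ring. Within the data shown here, the only measured step that bears on this is a 4.5-fold higher number from compound 1 to compound 3 (0.65 log units; beyond the scatter), where a carbonyl-linked group replaced a benzyl-type group on the same nitrogen and the number rose modestly. The change to compound 4 is of the same kind, so a modest rise beyond the scatter is expected, in this assay of a 2.2-fold higher number from compound 2 to compound 4 (0.34 log units; beyond the scatter). Compound 4 is therefore estimated at 200 nM, with a range from 80 nM to 500 nM.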

Compound 4, inhibition constant: 77.2 nM
Estimate against measurement, compound 4: 2.6-fold (0.41 log units) above, and the stated range ends above it.
By their numbers in this assay, from the lowest: compounds 1, 4, 2 and 3 (each within the scatter of the next, the first and the last beyond it).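

In this assay, on the sulfoxide compounds, the amine nitrogen in the ring takes (4-fluorophenyl)carbonyl in place of 2-hydroxy-3-phenylpropyl with no change outside the scatter: a 1.2-fold lower number from compound 2 to compound 4 (0.08 log units; within the scatter). A carbonyl link on this nitrogen therefore does not by itself bring a rise like a 4.5-fold higher number from compound 1 to compound 3 (0.65 log units; beyond the scatter), a step beyond the scatter that involves other groups and the thioether rather than the sulfoxide. Nothing measured here accounts for the difference between the two steps.

Open, as far as these compounds go, is whether the sulfur state changes what this nitrogen tolerates, which would need 4-chlorobenzyl on the sulfoxide or (4-fluorophenyl)carbonyl on the thioether. Also open, from the compounds shown here alone, is how a 4-fluorobenzyl group, the non-carbonyl match to compound 4, or a simple acetyl group would read at this position.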